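Swapping the aryl group on a spirocyclic diaminotriazine series

A few compounds are considered here, and "the series" means these few. Any claim that something is new, unique, unknown or untested is made for them only; others in the source may bear on it.

The compounds in this set share a spirocyclic triazine core carrying an aryloxypropyl chain, and they were tested in a functional assay on HepG2 cells (Homo sapiens) for antiproliferative activity, read by MTT assay, with a stated time of 72 h; a lower number here means a stronger inhibitor, a higher number a weaker inhibitor. Compound 1 `NC1=NC2(CCSCC2)N(OCCCOc2cccc(Cl)c2Cl)C(N)=N1` gives 50 nM in this assay. Going by the values given here, compound 3 `NC1=NC2(CCOCC2)N(OCCCOc2cccc(Cl)c2Cl)C(N)=N1`, which carries the same aryl group on a core with an oxygen in place of the sulfur, gives 330 nM in this assay; the gap between compound 1 and compound 3 is beyond the usual scatter, so compound 1 stands as the stronger of the two measured members. Compound 2 `Cc1ccc(OCCCON2C(N)=NC(N)=NC23CCOCC3)cc1` has "not determined" (no result reported) in this assay, so it adds nothing to the comparison.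

The step to compound 4 `NC1=NC2(CCSCC2)N(OCCCOc2ccccc2Br)C(N)=N1` keeps the sulfur-containing core of compound 1 and changes only the aryl group: 2-bromophenyl in place of 2,3-dichlorophenyl on an oxygen on a saturated carbon. Among the compounds with values here, no pair of measured compounds differs by this kind of change, so there is no directly comparable step to lean on. Given that compound 1 gives 50 nM, the author expects the loss of one halogen to cost a little activity, with the expected step of a 3.0-fold higher number from compound 1 to compound 4 (0.48 log units; beyond the scatter) pointing towards a somewhat higher number, possibly just beyond the scatter. Compound 4 is therefore estimated at 150 nM, within a range of 50 nM to 500 nM.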

Compound 4, half-maximal inhibitory concentration: 90 nM
The estimate for compound 4 lay 1.7-fold (0.22 log units) above the measured number; the measured number falls inside the stated range.
By their numbers in this assay, from the lowest: compounds 1 and 4 (each within the scatter of the next); then compound 3.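

In this assay the exchange of 2,3-dichlorophenyl for 2-bromophenyl on an oxygen on a saturated carbon gives a 1.8-fold higher number from compound 1 to compound 4 (0.26 log units; within the scatter) and so leaves the two numbers indistinguishable. Going by these compounds alone, this is the first reading of a change at this position, as the earlier numbers came from two compounds carrying the same aryl group, and it shows that on the core of compound 1 the number holds when one bromine takes the place of two chlorines, although this rests on a single pair. Nothing available explains why the two aryl groups read alike.

From the compounds shown here alone, whether 2-bromophenyl would behave the same way on the core of compound 3, where an oxygen stands in place of the sulfur, remains open, since one pair cannot show whether the aryl change carries over from one core to the other. Also open, going by these compounds, is how far this position accepts other groups, such as an unsubstituted phenyl, a methoxyphenyl or a pyridine ring, and whether a shorter or longer chain would leave the number where it is.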